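A few compounds are considered here, and "the series" means these few. Any claim that something is new, unique, unknown or untested is made for them only; others in the source may bear on it.

Measured compounds:
Compound 1, `CN1C[C@H](C(=O)Nc2ccc(F)cc2)[C@@H](c2ccc(/C=C/C(=O)Nc3ccccc3N)cc2)C1` — 34 mL/min/kg
Compound 2, `CC(C)c1ccc(NC(=O)[C@H]2CN(C)C[C@@H]2c2ccc(/C=C/C(=O)Nc3ccccc3N)cc2)cc1` — 54 mL/min/kg
Compound 3, `CN1C[C@H](C(=O)Nc2ccc(C(F)(F)F)cc2)[C@@H](c2ccc(/C=C/C(=O)Nc3ccccc3N)cc2)C1` — 23 mL/min/kg

In an in vitro ADME assay on microsomes from liver (Mus musculus) for pharmacokinetics, read by LC-MS, with a stated time of 10 min, tested at 1 uM (on this read-out lower numbers stand for slow clearance and higher numbers for fast clearance), compound 2 gives 54 mL/min/kg. Of the three measured compounds, compound 2 stands apart only from compound 3, with a 2.3-fold lower number from compound 2 to compound 3 (0.37 log units; beyond the scatter); its gap to compound 1, a 1.6-fold higher number from compound 1 to compound 2 (0.20 log units; within the scatter), remains within the scatter, so no order between compound 2 and compound 1 can be read from these numbers. Compound 1 and compound 3 likewise differ only within the scatter, a 1.5-fold lower number from compound 1 to compound 3 (0.17 log units; within the scatter).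

Compound 4, `CN1C[C@H](C(=O)Nc2ccccn2)[C@@H](c2ccc(/C=C/C(=O)Nc3ccccc3N)cc2)C1`, has not yet been measured in this assay. It differs from compound 2 in one place: pyridin-2-yl in place of 4-isopropylphenyl on an amide-type nitrogen. The measured steps that bear on this all alter the substituent on the same aromatic ring; the one beyond the scatter, a 2.3-fold lower number from compound 2 to compound 3 (0.37 log units; beyond the scatter), and the one within it, a 1.6-fold higher number from compound 1 to compound 2 (0.20 log units; within the scatter), both point from isopropyl toward a lower number. Since the new change removes the 4-isopropylphenyl group entirely, a modestly lower number is expected for compound 4, a 1.9-fold lower number from compound 2 to compound 4 (0.29 log units; within the scatter). Compound 4 is therefore estimated at 28 mL/min/kg, with a range from 14 mL/min/kg to 55 mL/min/kg.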

Compound 4, clearance: 40 mL/min/kg
Compound 4: middle estimate off by 1.4-fold (0.15 log units), on the low side, within the range that was stated.
By their numbers in this assay, from the lowest: compounds 3, 1, 4 and 2 (each within the scatter of the next, the first and the last beyond it).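

In this assay, among the compounds shown here, the earlier compounds changed only the substituent on a phenyl ring held on the amide-type nitrogen, whereas compound 4 replaces that whole aryl group with pyridin-2-yl, which brings in a ring nitrogen and a hydrogen-bond acceptor. This larger change gives no step beyond the scatter from any of the three earlier compounds (a 1.4-fold lower number from compound 2 to compound 4 (0.13 log units; within the scatter); a 1.7-fold higher number from compound 3 to compound 4 (0.24 log units; within the scatter); a 1.2-fold higher number from compound 1 to compound 4 (0.07 log units; within the scatter)), so no order can be read between compound 4 and any of them. No measurement shown here accounts for these numbers.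

The compounds shown leave open whether a pyrimidine ring or a saturated piperidine ring on the amide-type nitrogen would give a number within the scatter of these. They also leave open whether a methoxy group or a carboxylic acid on the pyridin-2-yl ring would produce a step beyond it.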